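This account rests on a few compounds, and the source may have more. Where it says the series, first, only, none or still open, it means among the compounds named here.

The measured compounds, each with its result in a functional assay on the whole organism (strain Wistar albino) for inhibition, with Rattus norvegicus as the target, read by paw edema, with stated times of 30 min and 90 min, at a dose of 50 mg/kg by the oral route; on this read-out higher numbers stand for more inhibition at the one dose given (going by the name of the read-out) and lower numbers for less inhibition:
Compound 1, `NS(=O)(=O)c1ccc(N2N=C(c3ccc(F)cc3)CC2c2cn(-c3ccccc3)nc2-c2ccccc2)cc1`, gives 23%.
Compound 2, `Cc1ccc(-c2nn(-c3ccccc3)cc2C2CC(c3ccccc3)=NN2c2ccc(S(N)(=O)=O)cc2)cc1`, gives 22%.
Compound 3, `Cc1ccc(C2=NN(c3ccc(S(N)(=O)=O)cc3)C(c3cn(-c4ccccc4)nc3-c3ccc(C)cc3)C2)cc1`, gives 16%.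

Compound 1 holds the highest of the three numbers, yet its nearest neighbour, compound 2, lies within the scatter of it, and even compound 3, the furthest, differs from it by no more than the scatter. The three values therefore cannot be set in any order.

Compound 4, `NS(=O)(=O)c1ccc(N2N=C(c3ccc(F)cc3)CC2c2cn(-c3ccccc3)nc2-c2ccc(F)cc2)cc1`, has not yet been measured in this assay. It differs from compound 1 in a single place: fluoro in place of hydrogen on an aromatic carbon.

Within the data shown here, only one measured step is available for comparison: a number 6 percentage points lower from compound 2 to compound 3 (within the scatter). That step concerns a methyl group rather than a fluoro, so it bears only loosely on the present change; what it shows is that one small substitution on an aromatic ring in this series moved the read-out by no more than the scatter. Among the measured compounds shown here, no step that puts fluoro in place of hydrogen is on hand. The expected step in this assay is therefore none beyond the scatter, the estimated change being a number 1 percentage points lower from compound 1 to compound 4 (within the scatter). Compound 4 is accordingly expected to give 22%, within a range from 12% to 32%.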

Compound 4, a percentage reported as inhibition, in the whole organism at one dose (the size of the read-out at that dose, not a potency): 16%
For compound 4 the middle estimate is 6 percentage points above the measured one; low and high end bracket the measured number.
By their numbers in this assay, from the lowest: compounds 3, 4, 2 and 1 (each within the scatter of the next).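

In this assay, the change from phenyl to 4-fluorophenyl gives a number 7 percentage points lower from compound 1 to compound 4 (within the scatter), and this is the only step shown that puts fluoro in place of hydrogen. The earlier compounds shown here gave only a methyl step, so this result adds that fluoro, on an aromatic carbon para to a large group, also leaves the read-out within the scatter, and no effect of this change on paw edema inhibition can be claimed from this single pair. Nothing available bears on a cause for this result.

The compounds shown leave open whether a different group at this same place, such as a methoxy group, an amine or a carboxylic acid, would move the read-out beyond the scatter. They also leave open whether fluoro would behave the same way on another aromatic ring of the core of compound 1, or at another position on this ring, since a single step at one place cannot settle either question.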